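The source may hold more compounds than are shown below. What is called first, only, known or untested is meant among the compounds shown, and "the series" means these compounds.

Compound 2 `Cc1n[nH]c(C)c1-c1cncc(-c2ccc(C(N)=O)c(OC(C)C)c2)c1` has the lowest number of the three measured compounds: in an assay on cells for inhibition of MAP kinase-interacting serine/threonine-protein kinase 2 (Homo sapiens), read by mobility shift assay, with stated times of 10 min and 60 min, in the presence of a further agent that is not named here (on this read-out lower numbers stand for stronger inhibition and higher numbers for weaker inhibition), compound 2 gives 14 nM. Compound 1 `CC(C)Oc1cc(-c2cncc(-c3cnn(C(C)C)c3)c2)ccc1C(N)=O` gives 42 nM in this assay, and compound 3 `NC(=O)c1ccc(-c2ccc(N)nc2)cc1` gives 13000 nM in this assay. Within the data shown here, the only measured step that changes a single group, a 3.0-fold lower number from compound 1 to compound 2 (0.48 log units; beyond the scatter), is a modest one. Compound 4 `CNC(=O)c1cncc(-c2ccc(C(N)=O)c(OC(C)C)c2)c1` has not yet been measured; it differs from compound 2 in methylcarbamoyl in place of 3,5-dimethyl-1H-pyrazol-4-yl on an aromatic carbon. The step from compound 1 to compound 2 bears on this only loosely, since it exchanges one pyrazole for another at the same carbon, whereas compound 4 gives up the ring for a small open-chain group. Among the measured compounds shown here, the values of compound 3 and compound 2 show how much the larger substituent contributes, but no single-change step leads from compound 3 to compound 4. A step to a higher number is therefore expected, a 14-fold higher number from compound 2 to compound 4 (1.15 log units; beyond the scatter). Compound 4 is thus estimated at 200 nM in this assay, with a range from 50 nM to 800 nM.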

Compound 4, half-maximal inhibitory concentration: 630 nM
The estimate for compound 4 lay 3.2-fold (0.50 log units) below the measured number; measured number inside the range.
By their numbers in this assay, from the lowest: compound 2; then compound 1; then compound 4; then compound 3.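

In this assay, the aromatic carbon two atoms from the ring nitrogen tolerates the loss of a pyrazole poorly: methylcarbamoyl in place of 3,5-dimethyl-1H-pyrazol-4-yl gives a 45-fold higher number from compound 2 to compound 4 (1.65 log units; beyond the scatter), and in place of 1-isopropyl-1H-pyrazol-4-yl it gives a 15-fold higher number from compound 1 to compound 4 (1.18 log units; beyond the scatter). Both are larger than the modest 3.0-fold lower number from compound 1 to compound 2 (0.48 log units; beyond the scatter), so at this carbon, going from a pyrazole to this open-chain group counts for more than exchanging one pyrazole for another. No measurement shown explains this loss, although the group that leaves and the group that enters have the same hydrogen-bond donor and acceptor counts.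

Going by these compounds, it remains open whether a ring as such is what matters at this carbon, which a phenyl or pyridine ring there could test against an open-chain group such as a dimethylamide or a primary carboxamide. The role of the amide hydrogen in methylcarbamoyl also stays unresolved.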